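Trimethoxyphenyl benzimidazole series: aryl swap at compound 4

The source may hold more compounds than are shown below. What is called first, only, known or untested is meant among the compounds shown, and "the series" means these compounds.

Measured compounds in a functional assay on MCF7 cells (Homo sapiens) for antiproliferative activity, read by MTT assay, with a stated time of 72 h; a higher number here means a weaker inhibitor, a lower number a stronger inhibitor:
compound 1 `COc1cc(-n2cnc3ccc(-c4cccc(N)c4)cc32)cc(OC)c1OC` gives 180 nM
compound 2 `COc1ccc(-c2ccc3ncn(-c4cc(OC)c(OC)c(OC)c4)c3c2)cc1F` gives 520 nM
compound 3 `COc1cc(-n2cnc3ccc(-c4ccc(Cl)cc4Cl)cc32)cc(OC)c1OC` gives 5420 nM

Compound 3 stands as the weakest of the three, its number above that of compound 2 by a 10-fold higher number from compound 2 to compound 3 (1.02 log units; beyond the scatter) and above that of compound 1 by a 30-fold higher number from compound 1 to compound 3 (1.48 log units; beyond the scatter), both beyond the scatter. Compound 4 `COc1cc(-n2cnc3ccc(-c4ccc(O)cc4)cc32)cc(OC)c1OC` differs from compound 3 in the aryl group: 4-hydroxyphenyl in place of 2,4-dichlorophenyl on an aromatic carbon. The two steps into compound 3 bear on this change; both were large and in the unfavourable direction, so leaving 2,4-dichlorophenyl is expected to reverse much of that loss. A 4-hydroxyphenyl is nearer in kind to 3-aminophenyl than to 2,4-dichlorophenyl, so compound 4 is estimated to land near compounds 1 and 2, a step of a 14-fold lower number from compound 3 to compound 4 (1.13 log units; beyond the scatter). Compound 4 is expected at 400 nM, range 150 nM to 1200 nM.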

Compound 4, half-maximal inhibitory concentration: 4160 nM
Compound 4: middle estimate off by 10-fold (1.02 log units), on the low side, and the stated range ends below it.
By their numbers in this assay, from the lowest: compound 1; then compound 2; then compounds 4 and 3 (each within the scatter of the next).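

In this assay 4-hydroxyphenyl in place of 2,4-dichlorophenyl leaves compound 3 and compound 4 within the scatter of each other (a 1.3-fold lower number from compound 3 to compound 4 (0.11 log units; within the scatter)), so gaining a hydrogen-bond donor and acceptor at this position does not by itself separate them. Compound 4 stays well apart from the two stronger aryl compounds (an 8.0-fold higher number from compound 2 to compound 4 (0.90 log units; beyond the scatter); a 23-fold higher number from compound 1 to compound 4 (1.36 log units; beyond the scatter)), so a hydroxyl-bearing phenyl does not match 3-aminophenyl or 3-fluoro-4-methoxyphenyl here. No independent measurement on hand accounts for this result. Still open, going by these compounds, is whether 3-hydroxyphenyl or 4-aminophenyl would sit nearer compound 1, which would separate the identity of the ring substituent from its place on the ring.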